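Two Dimethoxybenzoate Esters of a Shared Phenol Core

The source may hold more compounds than are shown below. What is called first, only, known or untested is meant among the compounds shown, and "the series" means these compounds.

In a functional assay on Jurkat E6.1 cells (Homo sapiens) for cytotoxicity, read by MTT assay, with a stated time of 24 h (a lower number here means a stronger inhibitor, a higher number a weaker inhibitor), compound 2 `COC(=O)/C(=C\c1ccc(OC(=O)c2ccc(OC)cc2OC)cc1)Sc1ccnc2cc(Cl)ccc12` gives 10200 nM, the highest of the two numbers obtained so far. Among the compounds with values here, its nearest neighbour is compound 1 `COC(=O)/C(=C\c1ccc(O)cc1)Sc1ccnc2cc(Cl)ccc12`, which gives 5180 nM, and the only measured step, a 2.0-fold higher number from compound 1 to compound 2 (0.29 log units; within the scatter), lies within the scatter. Compound 3 `COC(=O)/C(=C\c1ccc(OC(=O)c2cccc(OC)c2OC)cc1)Sc1ccnc2cc(Cl)ccc12` differs from compound 2 in one place: 2,3-dimethoxyphenyl in place of 2,4-dimethoxyphenyl on a carbonyl carbon. Within the data shown here, no measured step bears directly on this change, since a 2.0-fold higher number from compound 1 to compound 2 (0.29 log units; within the scatter) concerns the whole ester rather than its substitution pattern. Compound 3 is therefore expected to show no step beyond the scatter, a 1.1-fold lower number from compound 2 to compound 3 (0.05 log units; within the scatter). Compound 3 is estimated at 9000 nM, within a range from 3500 nM to 23000 nM.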

Compound 3, half-maximal inhibitory concentration: 25800 nM
Compound 3: the middle estimate sits 2.9-fold (0.46 log units) below what was measured; the whole stated range lies below it.
By their numbers in this assay, from the lowest: compounds 1 and 2 (each within the scatter of the next); then compound 3.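

In this assay, 2,3-dimethoxyphenyl in place of 2,4-dimethoxyphenyl on the carbonyl carbon gives a 2.5-fold higher number from compound 2 to compound 3 (0.40 log units; beyond the scatter) and so shows that, with the same atoms, the arrangement of the two methoxy groups can move the number beyond the scatter. The (2,3-dimethoxyphenyl)carbonyl group on the oxygen gives a 5.0-fold higher number from compound 1 to compound 3 (0.70 log units; beyond the scatter) while the 2,4-dimethoxy ester stays within the scatter of the free phenol. No evidence here accounts for this difference.

Going by these compounds, whether an amine or a carboxylic acid in place of either methoxy group would move the number further remains open.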